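A few compounds are considered here, and "the series" means these few. Any claim that something is new, unique, unknown or untested is made for them only; others in the source may bear on it.

Among the compounds with values here, compound 1 `O=C1NCCN(c2cccc(Cl)n2)N1` sits at the upper end of the two numbers seen so far: in a functional assay on cells for inhibition of Polyunsaturated fatty acid 5-lipoxygenase (Homo sapiens) (on this read-out higher numbers stand for weaker inhibition and lower numbers for stronger inhibition), compound 1 gives 4800 nM, and the only neighbour is compound 2 `CC1CN(c2cccc(Cl)n2)NC(=O)N1`, which gives 1600 nM. Within the data shown here, the one measured step, a 3.0-fold lower number from compound 1 to compound 2 (0.48 log units; beyond the scatter), is a modest move and comes from a methyl in place of hydrogen on a saturated ring carbon of the shared core.

Compound 3 `COc1cccc(N2CCNC(=O)N2)n1` differs from compound 1 elsewhere, on the aromatic ring: methoxy in place of chloro on an aromatic carbon, on an aromatic carbon of a six-membered aromatic ring with 1 nitrogen, next to the ring nitrogen and meta to a group of 7 heavy atoms. Among the measured compounds shown here, no measured step touches that aromatic position, so the step from compound 1 to compound 2 does not carry over to it and gives no direction for this exchange. With nothing to point either way, the expected step of no change at the digits printed from compound 1 to compound 3 (within the scatter) is none beyond the scatter, though the range must stay wide. Compound 3 is therefore estimated at 4800 nM in this assay, between 1600 nM and 14000 nM.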

Compound 3, half-maximal inhibitory concentration: 3500 nM
For compound 3 the middle estimate is 1.4-fold (0.14 log units) above the measured one, within the range that was stated.
By their numbers in this assay, from the lowest: compound 2; then compounds 3 and 1 (each within the scatter of the next).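

In this assay, the step with methoxy in place of chloro on an aromatic carbon, next to the ring nitrogen, is a 1.4-fold lower number from compound 1 to compound 3 (0.14 log units; within the scatter), so this exchange does not separate the two groups at this position. Within the data shown here, this is the first reading at this aromatic carbon, and the only step beyond the scatter in the set remains the one on the saturated ring carbon, a 3.0-fold lower number from compound 1 to compound 2 (0.48 log units; beyond the scatter). No supporting measurement bears on this result.

With only chloro and methoxy shown at this aromatic carbon, it remains open whether an amine, a carboxylic acid or a longer chain such as ethoxy would give a step beyond the scatter. Also open, on these data alone, is whether methoxy at this position and the methyl on the saturated ring carbon would act independently when carried together on the shared core.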